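Swapping the aryl group on a kinase inhibitor scaffold

The compounds below may be only part of what the source reports. "The series", "measured", "known", "first", "only" and "open" are said of these compounds alone.

Compound 2 `Cc1ccc(CC(CNC(C)C)C(=O)N2CCN(c3ncnc4c3[C@H](C)OC4)CC2)cc1`: 995 nM
Compound 1 `CC(C)NCC(Cc1ccc(Cl)c(F)c1)C(=O)N1CCN(c2ncnc3c2[C@H](C)SC3)CC1`: 92 nM

In an assay on LNCaP cells for inhibition of RAC-alpha serine/threonine-protein kinase (Homo sapiens) (a lower number here means a stronger inhibitor, a higher number a weaker inhibitor), compound 2 gives the higher of the two numbers, and compound 1 sits far lower, beyond the scatter. Compound 3 `CC(C)NCC(Cc1ccc(Cl)c(F)c1)C(=O)N1CCN(c2ncnc3c2[C@H](C)OC3)CC1` keeps the core of compound 2 and differs only in 4-chloro-3-fluorophenyl in place of 4-methylphenyl on a saturated chain carbon, two bonds along the chain from a carbonyl carbon. Compound 1 carries this same 4-chloro-3-fluorophenyl group on a differently built core and gives 92 nM, so the change is expected to lower the number, with the step of a 4.5-fold lower number from compound 2 to compound 3 (0.66 log units; beyond the scatter) estimated as clearly beyond the scatter. Compound 3 is therefore estimated at 220 nM, within 60 nM to 700 nM.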

Compound 3, half-maximal inhibitory concentration: 315 nM
Compound 3: middle estimate off by 1.4-fold (0.16 log units), on the low side, and the stated range covers the measured number.
By their numbers in this assay, from the lowest: compound 1; then compound 3; then compound 2.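

In this assay the move from 4-methylphenyl to 4-chloro-3-fluorophenyl on the shared core gives a 3.2-fold lower number from compound 2 to compound 3 (0.50 log units; beyond the scatter) and so shows that this chain position responds to the aryl group. With that aryl group held fixed, oxygen in place of sulfur in the core gives a 3.4-fold higher number from compound 1 to compound 3 (0.53 log units; beyond the scatter) and so shows that the aryl swap alone does not reach the lower number seen with the sulfur core. Nothing available explains either step. Still open, from the compounds shown here alone, is how a 4-methoxyphenyl or pyridyl group would compare at this position, and whether the sulfur core would give a lower number with 4-methylphenyl too.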